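The compounds below may be only part of what the source reports. "The series", "measured", "known", "first", "only" and "open" are said of these compounds alone.

Compound 1, `O=C(Nc1cccc(-c2oc3cc(-c4ccc(F)cc4)ccc3c(=O)c2O)c1)c1ccc(F)cc1`: 9280 nM
Compound 2, `COc1ccc(C(=O)Nc2cccc(-c3oc4cc(-c5ccc(F)cc5)ccc4c(=O)c3O)c2)cc1`: 8420 nM
Compound 3, `Cc1ccccc1C(=O)Nc1cccc(-c2oc3cc(-c4ccc(F)cc4)ccc3c(=O)c2O)c1`: 19400 nM

All three share one core and differ only in the aromatic ring carried on the amide carbonyl. In a functional assay on HepG2 cells (Homo sapiens) for antiproliferative activity, read by CCK-8 assay, with a stated time of 72 h (on this read-out lower numbers stand for stronger inhibition and higher numbers for weaker inhibition), compound 1 stands second highest of the three numbers; the nearest number is a 1.1-fold lower number from compound 1 to compound 2 (0.04 log units; within the scatter), the furthest is a 2.1-fold higher number from compound 1 to compound 3 (0.32 log units; beyond the scatter). Compound 4, `O=C(Nc1cccc(-c2oc3cc(-c4ccc(F)cc4)ccc3c(=O)c2O)c1)c1ccc(Br)cc1`, has not been measured; it differs from compound 1 by bromo in place of fluoro on an aromatic carbon. Among the measured compounds shown here, the one measured step that bears on this change is a 1.1-fold lower number from compound 1 to compound 2 (0.04 log units; within the scatter), which also alters the group at that same aromatic carbon and stays within the scatter, while the step to compound 3 replaces the whole ring. No step beyond the scatter is therefore expected in this assay, the expected step being a 1.1-fold lower number from compound 1 to compound 4 (0.04 log units; within the scatter). Compound 4 is estimated at 8500 nM, within a range from 4000 nM to 20000 nM.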

Compound 4, half-maximal inhibitory concentration: 13900 nM
The estimate for compound 4 lay 1.6-fold (0.21 log units) below the measured number, within the range that was stated.
By their numbers in this assay, from the lowest: compounds 2, 1, 4 and 3 (each within the scatter of the next, the first and the last beyond it).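

In this assay, a third group on the same aromatic carbon, para to a large group, gives a 1.5-fold higher number from compound 1 to compound 4 (0.18 log units; within the scatter) and a 1.7-fold higher number from compound 2 to compound 4 (0.22 log units; within the scatter), so these numbers do not separate fluoro, methoxy and bromo at this position. The 4-bromophenyl ring also stays within the scatter of the 2-methylphenyl ring, with a 1.4-fold lower number from compound 3 to compound 4 (0.14 log units; within the scatter), whereas the 4-fluorophenyl and 4-methoxyphenyl rings lay beyond it. No available measurement explains these small steps. From the compounds shown here alone, whether an amine, a carboxylic acid or a longer chain on this carbon would produce a step beyond the scatter remains open.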